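A few compounds are considered here, and "the series" means these few. Any claim that something is new, unique, unknown or untested is made for them only; others in the source may bear on it.

Measured so far, in a functional assay on HepG2 cells (Homo sapiens) for antiproliferative activity, with a stated time of 72 h; on this read-out higher numbers stand for an effect only at larger amounts of compound and lower numbers for an effect already at smaller amounts:

compound 1 `COc1ccc(-c2cc(=O)c3c(OC)cc(OC)cc3n2S(=O)(=O)c2cc(Cl)cc(Cl)c2O)cc1`: > 37900 nM
compound 2 `COc1cc(OC)c2c(=O)cc(C(=O)Nc3ccc(C4CCCCC4)cc3)[nH]c2c1`: > 43100 nM

Both entries are limits of this assay, not numbers. For compound 1 the value > 37900 nM is a limit, as marked by the limit of > 37900 nM in this assay, at which 1 of the 2 values shown sits. For compound 2 the value > 43100 nM is likewise a limit, as marked by the limit of > 43100 nM in this assay, at which 1 of the 2 values shown sits. For the measured compounds named here, compound 2 therefore stands nowhere on a scale of numbers: all that is known is that no half-maximal effect was reached within the tested range, and the only other value in the set is a limit as well, so no measured step exists and no ordering can be drawn.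

The next compound, compound 3 `COc1cc(OC)c2c(=O)cc(C(=O)Nc3ccc(Oc4cccnc4)cc3)[nH]c2c1`, keeps the shared core and the anilide of compound 2 and differs in one place: (pyridin-3-yl)oxy in place of cyclohexyl on an aromatic carbon. With both shown values sitting at limits, there is no measured step on which to size this change; the expectation is that the step from compound 2 to compound 3 stays an at least 1.0-fold lower number from compound 2 to compound 3 (0.03 log units; that floor lies within the scatter), that is, no movement resolved beyond the scatter, and that compound 3 most likely again returns a limit. Compound 3 is estimated at 40000 nM, with a range from 8000 nM to 100000 nM.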

Compound 3, half-maximal effective concentration: > 32100 nM
Compound 3 gave a limit, no number (the forecaster's own chance of this, stated with the estimate: 70%); the middle value does not contradict the limit.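

In this assay compound 3 gives > 32100 nM, a limit and not a number. Compound 2 also stands at a limit, so no step can be read between compound 2 and compound 3. The compounds shown leave open whether cyclohexyl and (pyridin-3-yl)oxy differ at all on this read-out, and which change to the series would yield a measured value.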